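The compounds below may be only part of what the source reports. "The series", "measured", "known", "first", "only" and "open" are said of these compounds alone.

In an ADME assay on HEK293 cells (Homo sapiens) for cytotoxicity, read by MTT assay, with a stated time of 24 h (a higher number here means a weaker inhibitor, a lower number a stronger inhibitor), compound 1 `O=C1O/C(=C\Cn2cc(Cc3ccccc3)nn2)C(OCc2ccccc2)=C1OCc1ccccc1` gives 70000 nM. For compound 2 `CC(C)(C)c1ccc(-c2cn(C/C=C3\OC(=O)C(OCc4ccccc4)=C3OCc3ccccc3)nn2)cc1` the result in this assay is a limit of the assay, > 100000 nM. The two differ by benzyl in place of 4-(tert-butyl)phenyl on an aromatic carbon, and the measured step is an at least 1.4-fold lower number from compound 2 to compound 1 (0.15 log units; that floor lies within the scatter); how far that step can be read is bounded by the limit of > 100000 nM in this assay, at which 2 of the 3 values shown sit. Compound 3 `CC(C)(C)c1ccc(-c2cn(CCC3(O)NC(=O)C(OCc4ccccc4)=C3OCc3ccccc3)nn2)cc1` carries a different core, and the difference between the cores of compound 3 and compound 2 is not broken down here. For compound 3 the result in this assay is likewise a limit of the assay, > 100000 nM. Compound 4 `O=C1NC(O)(CCn2cc(Cc3ccccc3)nn2)C(OCc2ccccc2)=C1OCc1ccccc1` has not yet been measured in this assay. It differs from compound 3 by benzyl in place of 4-(tert-butyl)phenyl on an aromatic carbon, the same change as between compound 2 and compound 1 and at the same place. Compound 4 is expected to show a step of an at least 1.1-fold lower number from compound 3 to compound 4 (0.04 log units; that floor lies within the scatter), set beside the measured at least 1.4-fold lower number from compound 2 to compound 1 (0.15 log units; that floor lies within the scatter), resting on the limit of > 100000 nM in this assay, at which 2 of the 3 values shown sit, and on the small size of that earlier step. Compound 4 is therefore estimated at 90000 nM, between 40000 nM and 200000 nM, with a real chance that only a limit is reported.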

Compound 4, half-maximal inhibitory concentration: 86000 nM
Compound 4: middle estimate off by 1.0-fold (0.02 log units), on the high side; measured number inside the range.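

In this assay, benzyl in place of 4-(tert-butyl)phenyl on an aromatic carbon now gives a second step on a different core, an at least 1.1-fold lower number from compound 3 to compound 4 (0.06 log units; that floor lies within the scatter). Both steps are only floors that lie within the scatter, so the pair shows that the change can be carried to the second core without a clear shift in the read-out, but it does not show that the change has a real effect on either core, nor that the cores differ: the same change on two cores in this assay, an at least 1.4-fold lower number (0.15 log units; that floor lies within the scatter) from compound 2 to compound 1 and an at least 1.1-fold lower number (0.06 log units; that floor lies within the scatter) from compound 3 to compound 4; the limit leaves it open whether they differ Compound 2 and compound 3 both stand at the limit of the assay, so the true size of either step stays unknown: the limit of > 100000 nM in this assay, at which 2 of the 4 values shown sit.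

The compounds shown leave open how either core would read if an amine or a carboxylic acid were carried on the phenyl ring of the group at this place. They also leave open what a longer chain linking the five-membered ring to the core would do to the read-out.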